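The source may hold more compounds than are shown below. What is called first, only, known or untested is meant among the compounds shown, and "the series" means these compounds.

Of the compounds shown here, two have numbers so far. Compound 1 `CN(C)CC[C@H](CSc1ccccc1)Nc1ccc(S(=O)(=O)Nc2cccc3cc(N4CCN(Cc5ccccc5-c5ccc(Cl)cc5)CC4)cnc23)cc1[N+](=O)[O-]` gives 68 nM in an assay on isolated protein for inhibition of Apoptosis regulator Bcl-2 (Homo sapiens), read by surface plasmon resonance, with a stated time of 1 h; on this read-out higher numbers stand for weaker inhibition and lower numbers for stronger inhibition. Compound 2 `CN(C)CC[C@H](CSc1ccccc1)Nc1ccc(S(=O)(=O)Nc2ncnc3c2CCN(C2CCN(Cc4ccccc4-c4ccc(Cl)cc4)CC2)C3)cc1S(=O)(=O)C(F)(F)F` gives 19 nM in this assay, the lowest of the two numbers; its nearest neighbour is compound 1, whose number is higher by a margin beyond the scatter. Compound 1 and compound 2 differ in more than one place, so the two values alone say nothing about any single change.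

Compound 3 `CC(c1ccccc1-c1ccc(Cl)cc1)N1CCC(N2CCc3c(ncnc3NS(=O)(=O)c3ccc(N[C@H](CCN(C)C)CSc4ccccc4)c(S(=O)(=O)C(F)(F)F)c3)C2)CC1` is not yet measured. It differs from compound 2 in one place: methyl in place of hydrogen on a saturated chain carbon bound to an amine nitrogen in a ring and an aromatic carbon. Going by the values given here, no measured pair in the set isolates this change. The change adds only one carbon and leaves donors, acceptors and charge as counted, so the expected step of a 1.1-fold higher number from compound 2 to compound 3 (0.02 log units; within the scatter) is none beyond the scatter, in either direction. Compound 3 is accordingly estimated at 20 nM in this assay, with an expected range from 8 nM to 50 nM.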

Compound 3, half-maximal inhibitory concentration: 35 nM
For compound 3 the middle estimate is 1.8-fold (0.24 log units) below the measured one; the range from low to high includes it.
By their numbers in this assay, from the lowest: compounds 2, 3 and 1 (each within the scatter of the next, the first and the last beyond it).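

In this assay, going by these compounds alone, methyl in place of hydrogen on a saturated chain carbon bound to an amine nitrogen in a ring and an aromatic carbon gives a 1.8-fold higher number from compound 2 to compound 3 (0.27 log units; within the scatter), the first step that isolates a single place. At this position, then, the added carbon produces no difference beyond the scatter, although that reading rests on this one pair alone. No measurement bearing on the reason for this result is available.

Open, from the compounds shown here alone, is whether the same position would hold its number with a larger or different group, such as an ethyl, a second methyl on the same carbon, or a hydroxyl. Also open, going by these compounds, is whether methyl at the corresponding carbon of compound 1, with its different core, would give a comparable step.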